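The compounds below may be only part of what the source reports. "The series", "measured", "known", "first", "only" and "open" are said of these compounds alone.

Compound 1 `COc1nc(-c2cccc(Cl)c2)ccc1[C@@H](c1ccccc1)[C@@](O)(CCN(C)C)c1cccc2ccccc12` gives > 50 ug/mL in a toxicity assay on Vero cells (Chlorocebus sabaeus) for cytotoxicity; a higher number here means that more compound is tolerated, a lower number that less compound is tolerated; this is a limit of the assay, not a number.
Compound 2 `COc1nc(-c2ccccc2F)ccc1[C@@H](c1ccccc1)[C@@](O)(CCN(C)C)c1cccc2ccccc12` gives > 50 ug/mL in this assay; this too is a limit.
Compound 3 `COc1ncc(-c2ccccc2)cc1[C@@H](c1ccccc1)[C@@](O)(CCN(C)C)c1cc(F)ccc1F` gives > 50 ug/mL in this assay, again a limit rather than a number.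

Compound 3 therefore stands where every value shown stands: at the limit of > 50 ug/mL in this assay, at which 3 of the 3 values shown sit, with no number to place it above or below its two neighbours. Compound 4 `COc1ncc(-c2ccccc2)cc1[C@@H](c1ccccc1)[C@@](O)(CCN(C)C)c1cccc2ccccc12` differs from compound 3 in a single place: naphthalen-1-yl in place of 2,5-difluorophenyl on a saturated chain carbon bound to an oxygen on a saturated carbon and two saturated chain carbons. Within the data shown here, the only measured step between two compounds that differ in one place is a step that the two limits leave unreadable from compound 1 to compound 2. Both of its ends are limits, and it cannot say how large a change of a ring at a saturated carbon may be. It does not touch the carbon that carries the alcohol oxygen, so it bears on the change to compound 4 only indirectly. What the three measurements do show is that compound 1 and compound 2 already carry naphthalen-1-yl at that carbon and are tolerated up to the limit. The step that the limit leaves unreadable from compound 3 to compound 4 is therefore expected to be none that the assay can read. For compound 4 the expected value is 60 ug/mL, within 35 ug/mL to 100 ug/mL, and most likely reported again only as a limit.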

Compound 4, half-maximal cytotoxic concentration: > 50 ug/mL
Compound 4 ended at the assay's limit; the forecaster's own chance of this, stated with the estimate: 80%; the middle value lies beyond the limit too.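

Compound 3 and compound 4 both end as limits in this assay, not as numbers, so no size can be read for the change from 2,5-difluorophenyl to naphthalen-1-yl: the limit of > 50 ug/mL in this assay, at which 4 of the 4 values shown sit. The compounds shown leave open the concentration at which any of them harms the cells, and whether any of these changes shifts it.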